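This account rests on a few compounds, and the source may have more. Where it says the series, first, only, none or still open, it means among the compounds named here.

Measured so far in an assay on mitochondria (strain BALB/c) for inhibition of glycerol-3-phosphate acyltransferase 1, mitochondrial (Mus musculus), read by scintillation counting, with a stated time of 10 min; on this read-out lower numbers stand for stronger inhibition and higher numbers for weaker inhibition:
compound 1, `CCCCCCCCS(=O)(=O)Nc1cc(-c2ccc(Cl)cc2)ccc1C(=O)O`: 18100 nM
compound 2, `CCCCCCCCS(=O)(=O)Nc1cc(C(=O)c2ccc(CCCC)cc2)ccc1C(=O)O`: 15800 nM
compound 3, `CCCCCCCCS(=O)(=O)Nc1ccc(C(=O)c2ccc(OC)cc2)cc1C(=O)O`: 44300 nM

Compound 1 stands second highest of these three numbers. Its nearest neighbour is compound 2, whose value lies within the scatter of that of compound 1, so the two cannot be told apart on this read-out. Compound 3 gives a number higher than that of compound 1, beyond the scatter. Among the measured compounds shown here, no pair of measured compounds differs in only one place, so no single-change step is available as a guide.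

Compound 4, `CCCCCCCCS(=O)(=O)Nc1cc(CCc2ccc(OC)cc2)ccc1C(=O)O`, is not yet measured. It differs from compound 1 by 2-(4-methoxyphenyl)ethyl in place of 4-chlorophenyl on an aromatic carbon. The shared core and the carboxy group are kept; only the aromatic substituent is exchanged. Nothing in the measured set isolates such a change. For the measured compounds named here, compound 3, the only other compound carrying a methoxyphenyl unit, holds it through a carbonyl link and gives 44300 nM, the highest number of the three. On that basis the step from compound 1 to compound 4 is expected to be small, a 1.3-fold higher number from compound 1 to compound 4 (0.12 log units; within the scatter), toward a somewhat higher number, with no change beyond the scatter also plausible. Compound 4 is expected to give about 24000 nM in this assay, with a range from 9000 nM to 65000 nM.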

Compound 4, half-maximal inhibitory concentration: 43000 nM
Compound 4: middle estimate off by 1.8-fold (0.25 log units), on the low side; measured number inside the range.
By their numbers in this assay, from the lowest: compounds 2 and 1 (each within the scatter of the next); then compounds 4 and 3 (each within the scatter of the next).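

In this assay, the aromatic carbon para to a carboxy group and meta to a large group now has its first single-change step: 2-(4-methoxyphenyl)ethyl in place of 4-chlorophenyl gives a 2.4-fold higher number from compound 1 to compound 4 (0.38 log units; beyond the scatter) and so a modest weakening of inhibition. The substituent at this position is therefore not indifferent to the read-out, although this one exchange alters the link, the group on the far ring and the size together, and the step cannot assign the shift to any one of these. Nothing available bears on the reason for the shift.

Going by these compounds, whether the shift follows from the ethyl link or from the methoxy group stays open, and a 4-methoxyphenyl or a 2-(4-chlorophenyl)ethyl group at this position would separate the two. Also open, on these data alone, is how this position responds to a group of a different kind, such as an amine, a carboxylic acid or a plain hexyl chain, and whether the same exchange would read alike on a core with a carbonyl link.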